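Chloro in Place of Trifluoromethyl, Tried a Second Time

This account rests on a few compounds, and the source may have more. Where it says the series, first, only, none or still open, it means among the compounds named here.

Of the compounds shown here, three on a shared core have been measured in a functional assay for agonist activity at Free fatty acid receptor 1 (Homo sapiens), read by FLIPR, in the presence of a further agent that is not named here; a lower number here means that less compound is needed, a higher number that more compound is needed for the effect. Compound 1 `O=C1NC(=O)C(Cc2ccc(Oc3ccc(C(F)(F)F)cn3)cc2)S1` gives 558 nM in this assay. Compound 3 `O=C1NC(=O)C(Cc2ccc(Oc3ccc(Cl)cn3)cc2)S1` differs from compound 1 by chloro in place of trifluoromethyl on an aromatic carbon; in this assay compound 3 gives 1870 nM, so that the step of a 3.4-fold higher number from compound 1 to compound 3 (0.53 log units; beyond the scatter). Compound 2 `O=C1NC(=O)C(Cc2ccc(Oc3ncc(C(F)(F)F)cc3Cl)cc2Cl)S1` carries two further chloro groups and gives 26 nM in this assay, the lowest of the three numbers and beyond the scatter from both others. The difference between the core of compound 2 and the core of compound 1 is not broken down here.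

Compound 4 `O=C1NC(=O)C(Cc2ccc(Oc3ncc(Cl)cc3Cl)cc2Cl)S1` has not yet been measured. It differs from compound 2 by chloro in place of trifluoromethyl on an aromatic carbon. Going by the values given here, this is the same kind of change as the one from compound 1 to compound 3, but not the same: in compound 4 the site is also meta to a chloro group, which it is not in compound 3. Among the compounds with values here, only one measured example of the change exists, so the expectation rests on it alone. The earlier change gave a 3.4-fold higher number from compound 1 to compound 3 (0.53 log units; beyond the scatter). A step of similar size is expected from compound 2 to compound 4, namely a 3.5-fold higher number from compound 2 to compound 4 (0.54 log units; beyond the scatter) in this assay. Compound 4 is therefore estimated at 90 nM in this assay, with a range from 40 nM to 220 nM that allows for the different surroundings of the changed carbon.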

Compound 4, half-maximal effective concentration: 63 nM
Compound 4: the middle estimate sits 1.4-fold (0.15 log units) above what was measured; the range from low to high includes it.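

In this assay, chloro in place of trifluoromethyl on the more heavily chlorinated core gives a 2.4-fold higher number from compound 2 to compound 4 (0.38 log units; beyond the scatter), so the number moves in the same direction as it did on the core of compound 1. Set side by side, the two steps cannot be told apart in size: the same change on two cores in this assay, a 3.4-fold higher number (0.53 log units; beyond the scatter) from compound 1 to compound 3 and a 2.4-fold higher number (0.38 log units; beyond the scatter) from compound 2 to compound 4, 1.4-fold (0.14 log units) apart, within the scatter of two such steps. Within this small set, then, the change carried from one core to the other with its direction and approximate size intact, even though compound 2 starts from a much lower number than compound 1; but two examples do not establish a rule for the series, and they do not show how the change would behave on any other core, nor do they explain why the number moves.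

The compounds shown leave open how a nitrile, a methyl or a methoxy group would compare with trifluoromethyl and chloro on the same aromatic carbon, two atoms from the ring nitrogen and para to a large group. They also leave open whether the step would keep its size on a core carrying only one of the two further chloro groups.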